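The source may hold more compounds than are shown below. What is called first, only, known or untested is meant among the compounds shown, and "the series" means these compounds.

Compound 3 `CCCCCCCc1ccc(NC(=O)N[C@H](C)c2ccccc2)cc1` gives 100% in an ADME assay on the whole organism with Oryza sativa as the target, tested at 0.1 uM (a higher number here means a weaker effect of the compound at the concentration tested, a lower number a stronger effect), level with compound 1 `Cc1ccc(NC(=O)N[C@H](C)c2ccccc2)cc1`, which gives 100%, and with compound 2 `C[C@@H](NC(=O)Nc1ccc(C(C)(C)C)cc1)c1ccccc1`, which gives 100%. Compound 4 `CCOC(=O)c1ccc(NC(=O)N[C@H](C)c2ccccc2)cc1` has not yet been measured. The change is ethoxycarbonyl in place of heptyl on an aromatic carbon. The steps seen so far at this carbon, no change at the digits printed from compound 1 to compound 3 (within the scatter) and no change at the digits printed from compound 2 to compound 3 (within the scatter), together with no change at the digits printed from compound 1 to compound 2 (within the scatter), all lay within the scatter, but none of them brought in the hydrogen-bond acceptors that an ethoxycarbonyl carries, so the change is only partly covered. Because no change at the digits printed from compound 2 to compound 3 (within the scatter) and no change at the digits printed from compound 1 to compound 3 (within the scatter) showed no change, no step beyond the scatter is expected for compound 4, whose step is estimated as no change at the digits printed from compound 3 to compound 4 (within the scatter). Compound 4 is therefore expected to give 100%, within 82% to 100%.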

Compound 4, a percentage reported as activity, at one concentration (the size of the read-out at that concentration, not a potency): 101%
Beside the measured number, compound 4's estimate is 1 percentage points below it, outside the stated range (above it).
By their numbers in this assay, from the lowest: compounds 1, 2, 3 and 4 (each within the scatter of the next).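

In this assay there is a number 1 percentage points higher from compound 3 to compound 4 (within the scatter) and a number 1 percentage points higher from compound 2 to compound 4 (within the scatter) and a number 1 percentage points higher from compound 1 to compound 4 (within the scatter) on placing ethoxycarbonyl on this aromatic carbon. Hydrogen-bond acceptors at this carbon, which heptyl does not carry, thus leave the read-out within the scatter, as the earlier alkyl changes did. No measurement at hand bears on this result. All four compounds stand level at the single concentration tested, so no step beyond the scatter is available to read. As far as these compounds go, whether an amine or a carboxylic acid on this carbon, or a change elsewhere on the shared core, would move the number remains open.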